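A few compounds are considered here, and "the series" means these few. Any claim that something is new, unique, unknown or untested is made for them only; others in the source may bear on it.

Working notes on the amide series. The shared core carries a 4-chlorophenyl and a dimethylaminoethyl group on the carbon next to the amide nitrogen, and the three measured compounds differ only in the aryl on the carbonyl carbon. In an assay on NIH3T3 cells with Urotensin-2 receptor (Homo sapiens) as the target (on this read-out higher numbers stand for an effect only at larger amounts of compound and lower numbers for an effect already at smaller amounts), compound 1 `Cc1cccc(C(=O)NC(CCN(C)C)c2ccc(Cl)cc2)c1C` gives 3630 nM, compound 2 `Cc1c(Cl)cccc1C(=O)NC(CCN(C)C)c1ccc(Cl)cc1` gives 1740 nM, and compound 3 `Cc1ccc(C(=O)NC(CCN(C)C)c2ccc(Cl)cc2)c(C)c1` gives 1550 nM. Compound 3 has the lowest of the three numbers in this assay, but its separation from compound 2 is within the scatter, so no order between these two is claimed; only compound 1 stands apart, a 2.3-fold lower number from compound 1 to compound 3 (0.37 log units; beyond the scatter).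

Compound 4 `Cc1cccc(Cl)c1C(=O)NC(CCN(C)C)c1ccc(Cl)cc1` is the next step: 2-chloro-6-methylphenyl in place of 2,4-dimethylphenyl on a carbonyl carbon. For the measured compounds named here, two measured steps touch this change. Chloro in place of methyl on the aryl gave a 2.1-fold lower number from compound 1 to compound 2 (0.32 log units; beyond the scatter), and rearranging the two methyl groups gave a 2.3-fold lower number from compound 1 to compound 3 (0.37 log units; beyond the scatter), while a 1.1-fold lower number from compound 2 to compound 3 (0.05 log units; within the scatter). Going by the values given here, both ring changes measured so far moved the number modestly in the same direction, but no measured compound carries substituents on both carbons flanking the attachment, so the new pattern has no direct precedent. A modest step at most is expected, direction open; for compound 4 the estimate in this assay is 1800 nM, range 600 nM to 5500 nM, i.e. a 1.2-fold higher number from compound 3 to compound 4 (0.06 log units; within the scatter).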

Compound 4, half-maximal effective concentration: 5130 nM
Compound 4: middle estimate off by 2.9-fold (0.45 log units), on the low side, and the stated range covers the measured number.
By their numbers in this assay, from the lowest: compounds 3 and 2 (each within the scatter of the next); then compounds 1 and 4 (each within the scatter of the next).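

In this assay the 2-chloro-6-methylphenyl group on the carbonyl carbon gives up the lower numbers seen with the other two aryl groups (a 3.3-fold higher number from compound 3 to compound 4 (0.52 log units; beyond the scatter); a 2.9-fold higher number from compound 2 to compound 4 (0.47 log units; beyond the scatter)), and compound 4 cannot be separated from compound 1 (a 1.4-fold higher number from compound 1 to compound 4 (0.15 log units; within the scatter)). Compound 2 and compound 4 both carry one chloro and one methyl on the aryl, so at this position the arrangement of the two groups matters and the presence of chloro alone does not give the lower number. No measurement shown here gives a reason for this step.

As far as these compounds go, whether a 2,6-dimethylphenyl or a 2,6-dichlorophenyl group would behave like the 2-chloro-6-methylphenyl group stays open, so the result cannot yet be tied to the arrangement in general or to this pair of groups. Also open, from the compounds shown here alone, is how the number responds to a methoxy group, a nitrile or an amine on the aryl.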